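The source may hold more compounds than are shown below. What is called first, only, known or untested is meant among the compounds shown, and "the series" means these compounds.

Of the compounds shown here, three that share one core have been measured in a functional assay on NCI-H460 cells (Homo sapiens) for inhibition, read by MTT assay, with a stated time of 72 h; on this read-out higher numbers stand for weaker inhibition and lower numbers for stronger inhibition. Compound 3 `COc1cc2c(Oc3ccc(NC(=O)c4nn(-c5ccccc5OC(F)(F)F)c(=O)cc4C)cc3F)ccnc2cc1OCCCN1CCC(C)CC1` gives 290 nM, the second highest of the three numbers. Its nearest neighbour is compound 2 `COc1cc2c(Oc3ccc(NC(=O)c4nn(-c5ccccc5OC(F)(F)F)c(=O)cc4C)cc3F)ccnc2cc1OCCCN1CCCCC1`, which gives 230 nM; the two differ only by a methyl group, and the step of a 1.3-fold higher number from compound 2 to compound 3 (0.10 log units; within the scatter) lies within the scatter. Compound 1 `COc1cc2c(Oc3ccc(NC(=O)c4nn(-c5ccccc5C)c(=O)cc4C)cc3F)ccnc2cc1OCCCN1CCN(C)CC1` gives 3420 nM, the furthest of the three from compound 3. Compound 1 differs from compound 2 in two places at once, a methyl in place of a trifluoromethoxy group and a different saturated amine ring, so no single step can be read from that pair.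

Compound 4 `COc1cc2c(Oc3ccc(NC(=O)c4nn(-c5ccccc5OC(F)(F)F)c(=O)cc4C)cc3F)ccnc2cc1OCCCN1CCN(C)CC1` has not yet been measured. It differs from compound 3 by 4-methylpiperazin-1-yl in place of 4-methylpiperidin-1-yl on a saturated chain carbon, three bonds along the chain from an oxygen on an aromatic ring. Within the data shown here, no measured step isolates this change: the only single step available, a 1.3-fold higher number from compound 2 to compound 3 (0.10 log units; within the scatter), concerns a methyl on the amine ring and was small, while compound 1, which carries the same amine ring as compound 4, also carries a different aromatic substituent, so its much higher number cannot be assigned to the ring alone. The step of a 1.7-fold higher number from compound 3 to compound 4 (0.24 log units; within the scatter) is therefore expected to be modest, with its direction uncertain. Compound 4 is estimated at 500 nM, within a range from 150 nM to 2000 nM.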

Compound 4, half-maximal inhibitory concentration: 260 nM
Beside the measured number, compound 4's estimate is 1.9-fold (0.28 log units) above it, within the range that was stated.
By their numbers in this assay, from the lowest: compounds 2, 4 and 3 (each within the scatter of the next); then compound 1.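

In this assay, placing 4-methylpiperazin-1-yl on a saturated chain carbon, three bonds along the chain from an oxygen on an aromatic ring, gives a 1.1-fold lower number from compound 3 to compound 4 (0.05 log units; within the scatter) when it replaces 4-methylpiperidin-1-yl, and a 1.1-fold higher number from compound 2 to compound 4 (0.05 log units; within the scatter) when it replaces piperidin-1-yl. Among these three compounds, which all carry trifluoromethoxy, a ring with 2 hetero atoms at this place therefore gives no readable difference from a ring with 1. Compound 4 also supplies the missing one-place comparison with compound 1, since both carry the same amine ring, and the large step, a 13-fold lower number from compound 1 to compound 4 (1.12 log units; beyond the scatter), ties the high number of compound 1 to methyl in place of trifluoromethoxy on the aromatic carbon rather than to the amine ring, though the data offer no explanation for any of these steps.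

The compounds shown leave open whether a morpholine ring, an open-chain dimethylamino group or a shorter chain would fit this place equally well. They also leave open whether the amine ring would remain without readable effect in compounds carrying methyl instead of trifluoromethoxy.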